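The source may hold more compounds than are shown below. What is called first, only, known or untested is meant among the compounds shown, and "the series" means these compounds.

Measured in a functional assay on SN12C cells (Homo sapiens) for cytotoxicity, read by sulforhodamine B assay, with a stated time of 48 h, tested at 0.01 uM; on this read-out lower numbers stand for a stronger effect and higher numbers for a weaker effect at the one concentration tested:
- compound 1 `COc1ccc(-c2cc(/C=C/C(=O)c3ccc(N)cc3)[nH]n2)cc1`: 93%
- compound 2 `COc1cc(-c2cc(/C=C/C(=O)c3ccc(N)cc3)[nH]n2)cc(OC)c1OC`: 98%
- compound 3 `COc1ccc(C(=O)/C=C/c2cc(-c3cc(OC)c(OC)c(OC)c3)n[nH]2)cc1`: 99%

Compound 2 stands second highest of the three numbers in this assay. Its nearest neighbour is compound 3, a number one step higher that is given as within the scatter; its furthest neighbour is compound 1, with a gap that is also given as within the scatter. The three numbers shown so far therefore sit in one band, and no compound of the three can be called stronger or weaker than another on this read-out.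

Compound 4 `COc1ccc(-c2cc(/C=C/C(=O)c3ccc(N)cc3)[nH]n2)cc1OC` is not yet measured. It arises from compound 2 by hydrogen in place of methoxy on an aromatic carbon. Among the compounds with values here, the one measured step that touches the same region of the molecule is a number 1 percentage points higher from compound 2 to compound 3 (within the scatter), which concerns a different change on a different ring and is within the scatter. Compound 1, which carries a single methoxy on the ring in question, and compound 2, which carries three, give numbers that differ only within the scatter. Nothing shown so far suggests that the count of methoxy groups on this ring moves the read-out.

The step from compound 2 to compound 4 is expected to be none beyond the scatter, a number 2 percentage points lower from compound 2 to compound 4 (within the scatter). For compound 4 the estimate in this assay is 96%, with a range from 88% to 103%.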

Compound 4, a percentage reported as activity, at one concentration (the size of the read-out at that concentration, not a potency): 101%
Compound 4: the middle estimate sits 5 percentage points below what was measured, within the range that was stated.
By their numbers in this assay, from the lowest: compounds 1, 2, 3 and 4 (each within the scatter of the next).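

In this assay, removing the methoxy that sits ortho to a methoxy group and meta to a large group gives a number 3 percentage points higher from compound 2 to compound 4 (within the scatter), and adding a methoxy to the same ring from the other side gives a number 8 percentage points higher from compound 1 to compound 4 (within the scatter). Compounds 1 and 2 differ in two places, so they could not isolate a single methoxy on this ring, whereas compound 4 joins them through two single-place changes, and neither step leaves the scatter. These steps show that, at the one concentration tested, this methoxy can be exchanged for hydrogen with no readable effect on the read-out, but no accompanying measurement bears on the reason for that.

Going by these compounds, all four compounds lie in one band at this single concentration, so it remains open whether this methoxy would matter under conditions where the read-out departs from that band. Also open, on these data alone, is how this place on the ring would respond to a group other than methoxy or hydrogen, such as a hydroxy, a fluorine, an ethoxy or an amine.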